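Working notes: tert-butyl in place of fluoro

The source may hold more compounds than are shown below. What is called first, only, known or untested is meant among the compounds shown, and "the series" means these compounds.

- compound 1 `COc1cccc(CNCCCNc2ccnc3cc(Oc4ccccc4)ccc23)c1O`: 9.28
- compound 2 `COc1ccc(-c2ccc3c(NCCCNCc4cccc(OC)c4O)ccnc3c2)cc1`: 9.47
- compound 3 `COc1cccc(CNCCCNc2ccnc3cc(Oc4ccc(F)cc4)ccc23)c1O`: 9.28

In a physicochemical assay for acid dissociation, compound 3 gives 9.28, level with compound 1 at the digits shown. It differs from the remaining measured compound by a number 0.19 log units lower from compound 2 to compound 3 (within the scatter).

The next structure is compound 4 `COc1cccc(CNCCCNc2ccnc3cc(Oc4ccc(C(C)(C)C)cc4)ccc23)c1O`, with tert-butyl in place of fluoro on an aromatic carbon, para to a large group: tert-butyl in place of fluoro on an aromatic carbon. In other words, 4-fluorophenoxy gives way to 4-(tert-butyl)phenoxy.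

The closest measured change is a substitution at the phenoxy group, fluoro in place of hydrogen, which gave no change at the digits printed from compound 1 to compound 3 (within the scatter). A larger exchange, 4-methoxyphenyl in place of phenoxy, gave a number 0.19 log units higher from compound 1 to compound 2 (within the scatter). Among the measured compounds shown here, no measured compound carries tert-butyl, so the expectation rests on these small steps alone.

The expected step is a number 0.02 log units higher from compound 3 to compound 4 (within the scatter), with nothing expected beyond the scatter. For compound 4 the estimated value is 9.3, with an expected range from 9.05 to 9.55.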

Compound 4, acid dissociation constant: 9.28
Estimate against measurement, compound 4: 0.02 log units above; measured number inside the range.
By their numbers in this assay, from the lowest: compounds 1, 3, 4 and 2 (each within the scatter of the next).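

In this assay, the aromatic carbon para to a large group now carries tert-butyl, with 4 heavy atoms against 1 for fluoro, and the step reads no change at the digits printed from compound 3 to compound 4 (within the scatter) in this series. Against the unsubstituted phenoxy the result is the same, no change at the digits printed from compound 1 to compound 4 (within the scatter), so hydrogen, fluoro and tert-butyl at this position give the same number at the digits printed. The exchange of 4-methoxyphenyl for 4-(tert-butyl)phenoxy reads a number 0.19 log units lower from compound 2 to compound 4 (within the scatter) and also stays inside the scatter. No available evidence bears on the reason for this result.

From the compounds shown here alone, whether an amine or a carboxylic acid on this aromatic carbon would shift the number beyond the scatter remains open. So does the response of this read-out to a longer chain between the shared core and the methoxyphenol end.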